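Ethyl Versus Methyl on the Ring Nitrogen of a Cytotoxic Series

The source may hold more compounds than are shown below. What is called first, only, known or untested is meant among the compounds shown, and "the series" means these compounds.

Compound 1 `CCn1c(/C=C2/C(=O)Nc3ccc(F)cc32)nc2ccccc21`: in a functional assay on MDA-MB-231 cells (Homo sapiens) for cytotoxicity, read by MTT assay, with a stated time of 48 h (a higher number here means a weaker inhibitor, a lower number a stronger inhibitor), compound 1 reaches only a limit, > 50000 nM.
Compound 2 `Cn1c(/C=C2/C(=O)Nc3ccc(F)cc32)nc2ccccc21`: compound 2 gives 21700 nM.
Compound 3 `Cn1c(/C=C2/C(=O)Nc3ccc(Cl)cc32)nc2ccccc21`: compound 3 gives 37600 nM.

The three measured compounds share one core and differ in two places. Between compound 2 and compound 3 the change is chloro in place of fluoro on an aromatic carbon, and the step is a 1.7-fold higher number from compound 2 to compound 3 (0.24 log units; within the scatter). Between compound 2 and compound 1 the change is methyl in place of hydrogen on a saturated chain carbon bound to an aromatic nitrogen, and the step is an at least 2.3-fold higher number from compound 2 to compound 1 (0.36 log units; beyond the scatter); its size rests on (the limit of > 50000 nM in this assay, at which 1 of the 3 values shown sits), so only a lower bound of the weakening is known.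

Compound 4 `CCn1c(/C=C2/C(=O)Nc3ccc(Cl)cc32)nc2ccccc21` has not yet been measured in this assay . It differs from compound 3 by methyl in place of hydrogen on a saturated chain carbon bound to an aromatic nitrogen, the same change as that between compound 2 and compound 1, at the same place. For compound 4 a step of a 2.4-fold higher number from compound 3 to compound 4 (0.38 log units; beyond the scatter) is expected, similar to or larger than the earlier one. This expectation rests on compound 3 at 37600 nM and on the step of an at least 2.3-fold higher number from compound 2 to compound 1 (0.36 log units; beyond the scatter). Compound 4 is therefore estimated at 90000 nM, with a range from 45000 nM to 200000 nM, most likely reported only as a limit.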

Compound 4, half-maximal inhibitory concentration: 37500 nM
Beside the measured number, compound 4's estimate is 2.4-fold (0.38 log units) above it, and the stated range ends above it.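

In this assay, carrying methyl in place of hydrogen on a saturated chain carbon bound to an aromatic nitrogen over to the chloro compounds gives a 1.0-fold lower number from compound 3 to compound 4 (0.00 log units; within the scatter), so the ethyl compound cannot be told apart from its methyl partner there. This shows that the clear weakening seen with the fluoro compounds does not reappear on the chloro compounds, but it does not show that the two cores truly respond differently: the same change on two cores in this assay, an at least 2.3-fold higher number (0.36 log units; beyond the scatter) from compound 2 to compound 1 and a 1.0-fold lower number (0.00 log units; within the scatter) from compound 3 to compound 4; the limit leaves it open whether they differ Read the other way, chloro in place of fluoro on the two ethyl compounds gives an at least 1.3-fold lower number from compound 1 to compound 4 (0.12 log units; that floor lies within the scatter), and this comparison is no more decisive: the same change on two cores in this assay, a 1.7-fold higher number (0.24 log units; within the scatter) from compound 2 to compound 3 and an at least 1.3-fold lower number (0.12 log units; that floor lies within the scatter) from compound 1 to compound 4; the limit leaves it open whether they differ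

The true size of the step among the fluoro compounds stays open: the limit of > 50000 nM in this assay, at which 1 of the 4 values shown sits. The compounds shown also leave open how a propyl chain in place of the ethyl, or a bromo or methoxy group in place of the halogen, would read in this assay.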